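A few compounds are considered here, and "the series" means these few. Any claim that something is new, unique, unknown or untested is made for them only; others in the source may bear on it.

Compound 3 `OC1CCN(c2nc(-c3cc(-c4ccon4)n(Cc4ccccc4F)n3)ncc2F)CC1` gives 10 nM in an assay on a protein complex for activation of soluble guanylate cyclase (Homo sapiens), read by cGMP accumulation, in the presence of a further agent that is not named here (a higher number here means that more compound is needed for the effect, a lower number that less compound is needed), the lowest of the three numbers at hand. Compound 1 `Fc1ccccc1Cn1nc(-c2ncc(F)c(N3CCCCC3)n2)cc1-c1ccon1` gives 27 nM in this assay, and compound 2 `Fc1ccccc1Cn1nc(-c2ncc(F)c(N3CCC(F)(F)CC3)n2)cc1-c1ccon1` gives 250 nM in this assay. The steps among them: a 2.7-fold lower number from compound 1 to compound 3 (0.43 log units; beyond the scatter); a 9.3-fold higher number from compound 1 to compound 2 (0.97 log units; beyond the scatter); a 25-fold lower number from compound 2 to compound 3 (1.40 log units; beyond the scatter).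

Compound 4 `OCC1CCCCN1c1nc(-c2cc(-c3ccon3)n(Cc3ccccc3F)n2)ncc1F` differs from compound 3 in one place: 2-(hydroxymethyl)piperidin-1-yl in place of 4-hydroxypiperidin-1-yl on an aromatic carbon. Going by the values given here, no measured pair shows a hydroxymethyl on the saturated ring, nor a substituent at that ring carbon, so the step has no direct precedent. The step that bears on it most is a 2.7-fold lower number from compound 1 to compound 3 (0.43 log units; beyond the scatter), which shows that a hydroxy on the saturated ring is worth a modest gain over hydrogen in this assay; the other two steps concern the difluoro exchange and do not speak to this change. Compound 4 keeps one hydroxy and one saturated ring, so a result of the same order as compound 3 is expected, with a modest drift toward a higher number more likely than a further gain, as a 3.0-fold higher number from compound 3 to compound 4 (0.48 log units; beyond the scatter). Compound 4 is therefore estimated at 30 nM in this assay, with a range of 8 nM to 120 nM.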

Compound 4, half-maximal effective concentration: 35 nM
Compound 4: the middle estimate sits 1.2-fold (0.07 log units) below what was measured; low and high end bracket the measured number.
By their numbers in this assay, from the lowest: compound 3; then compounds 1 and 4 (each within the scatter of the next); then compound 2.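

At the aromatic carbon next to the ring nitrogen and ortho to a fluoro group, 2-(hydroxymethyl)piperidin-1-yl does not match 4-hydroxypiperidin-1-yl in this assay (a 3.5-fold higher number from compound 3 to compound 4 (0.54 log units; beyond the scatter)), and hydroxymethyl on the saturated ring carbon gives no readable change from the unsubstituted piperidin-1-yl (a 1.3-fold higher number from compound 1 to compound 4 (0.11 log units; within the scatter)). A hydroxy-bearing group at this position is therefore not enough on its own to give the gain seen with compound 3. The 4,4-difluoropiperidin-1-yl group still stands apart from this new group (a 7.1-fold lower number from compound 2 to compound 4 (0.85 log units; beyond the scatter)), and no measurement at hand accounts for these differences.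

The step to compound 4 changes both the ring carbon that carries the oxygen and the chain that holds it, so these two changes cannot be separated here; 4-(hydroxymethyl)piperidin-1-yl or 3-hydroxypiperidin-1-yl would divide them. From the compounds shown here alone, whether the hydroxy itself is required also remains open, and 4-methoxypiperidin-1-yl or 4-aminopiperidin-1-yl at the same position would address that.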